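A few compounds are considered here, and "the series" means these few. Any claim that something is new, unique, unknown or untested is made for them only; others in the source may bear on it.

Compound 1 `c1cncc(-c2ccccc2OCC2=NCCN2)c1` gives 109% in a functional assay with Alpha-1A adrenergic receptor (Homo sapiens) as the target, read by calcium flux; a higher number here means a larger maximal response, a lower number a smaller maximal response.
Compound 2 `c1cnc(-c2ccccc2OCC2=NCCN2)nc1` gives 90% in this assay.

Compound 2 stands lowest of the two, set apart from compound 1 by the step of a number 19 percentage points lower from compound 1 to compound 2 (beyond the scatter). Compound 3 `c1ccc(-c2cnccn2)c(OCC2=NCCN2)c1` differs from compound 2 by pyrazin-2-yl in place of pyrimidin-2-yl on an aromatic carbon. Within the data shown here, that single measured step concerned a different ring exchange, pyridin-3-yl for pyrimidin-2-yl, so no measured step bears directly on the change here. A step within the scatter, in either direction, is therefore expected in this assay. Compound 3 is estimated to give 92%, between 70% and 112%, an expected step of a number 2 percentage points higher from compound 2 to compound 3 (within the scatter).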

Compound 3, largest response reached (reported as maximum), in percent of the reference or control that the assay uses: 97%
Compound 3: the middle estimate sits 5 percentage points below what was measured, within the range that was stated.
By their numbers in this assay, from the lowest: compounds 2 and 3 (each within the scatter of the next); then compound 1.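

In this assay, moving from pyrimidin-2-yl to pyrazin-2-yl, two rings with the same atoms joined differently, gives a number 7 percentage points higher from compound 2 to compound 3 (within the scatter) and so no readable change at this position. Pyrazin-2-yl, measured against pyridin-3-yl, gives a number 12 percentage points lower from compound 1 to compound 3 (beyond the scatter) and so joins pyrimidin-2-yl in falling short of that ring. No measurement here offers an explanation for either step.

Going by these compounds, whether a plain phenyl ring would match pyridin-3-yl or the two rings with two hetero atoms remains open. So does the effect of adding an amine or a methoxy group to any of these rings.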